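The source may report more compounds than this note shows. Statements on the series, on what has been measured and on what is new or still open speak of the compounds shown alone.

Of the compounds shown here, two have numbers so far. In a functional assay (blood) for inhibition, with Homo sapiens as the target (a higher number here means a weaker inhibitor, a lower number a stronger inhibitor), compound 1 (`O=C(Nc1ccc(-n2nc(C(F)(F)F)cc2Br)cc1)c1ccncc1F`) gives 288 nM and compound 2 (`O=C(Nc1ccc(-n2nc(C(F)(F)F)cc2[N+](=O)[O-])cc1)c1ccncc1F`) gives 440 nM on the same core. Compound 2 therefore stands within the scatter of compound 1, and the two values cannot be told apart. The next change leads to compound 3 (`O=C(Nc1ccc(-n2nc(C(F)(F)F)cc2OC(F)F)cc1)c1ccncc1F`), with difluoromethoxy in place of nitro on an aromatic carbon. Within the data shown here, the only measured step at this place is nitro in place of bromo (a 1.5-fold higher number from compound 1 to compound 2 (0.18 log units; within the scatter)), and it stays within the scatter. Among the measured compounds shown here, a single step between two compounds is thin evidence, and no compound carrying difluoromethoxy has been measured yet. On the evidence of compound 2 at 440 nM and that small step, no change beyond the scatter is expected in this assay and no direction can be argued with confidence. The estimated move is small (a 1.3-fold lower number from compound 2 to compound 3 (0.11 log units; within the scatter)). For compound 3 the expected value is 340 nM (estimated range 130 nM to 850 nM).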

Compound 3, half-maximal inhibitory concentration: 182 nM
The estimate for compound 3 lay 1.9-fold (0.27 log units) above the measured number, and the stated range covers the measured number.
By their numbers in this assay, from the lowest: compounds 3, 1 and 2 (each within the scatter of the next, the first and the last beyond it).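

In this assay, this position, on an aromatic carbon of the five-membered ring and next to the ring nitrogen, now gives its first step beyond the scatter (a 2.4-fold lower number from compound 2 to compound 3 (0.38 log units; beyond the scatter)), with difluoromethoxy in place of nitro. Among these compounds, that step is modest, and the other new comparison stays within the scatter (a 1.6-fold lower number from compound 1 to compound 3 (0.20 log units; within the scatter)): difluoromethoxy and bromo cannot be told apart here, and only the pair of difluoromethoxy and nitro is separated, even though bromo and nitro themselves also lie within the scatter of each other. No measurement of any property of these groups accompanies the result, and nothing on hand accounts for the step.

As far as these compounds go, what an amine, a carboxylic acid or a longer alkoxy chain would give at this position stays open, so three groups mark out only a narrow part of what the position might accept. Also open, from the compounds shown here alone, is whether the step from nitro to difluoromethoxy would hold with a group other than trifluoromethyl two ring bonds away, since that group is the same in all three compounds.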